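Aryl swap at the imidazopyrazine core: ethylphenyl to methylphenyl

The source may hold more compounds than are shown below. What is called first, only, known or untested is meant among the compounds shown, and "the series" means these compounds.

Two compounds in this series have numbers in a functional assay on MOLT-4 cells (Homo sapiens) for inhibition, read by sulforhodamine B assay, with a stated time of 48 h, tested at 10 uM; on this read-out lower numbers stand for less inhibition and higher numbers for more inhibition at the one concentration tested (going by the name of the read-out). Compound 1 `COc1ccccc1-c1cn2ccnc2c(-c2ccc3ncn(C4CCCCC4)c3c2)n1` gives 22.4% in this assay. Compound 2 `CCc1ccc(-c2cn3ccnc3c(-c3ccc4ncn(Cc5ccccc5)c4c3)n2)cc1` gives 54.2% in this assay, the higher of the two numbers, and its gap to compound 1 lies beyond the scatter; the two differ in more than one place, so the gap cannot be assigned to a single change.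

Compound 3 `Cc1cccc(-c2cn3ccnc3c(-c3ccc4ncn(Cc5ccccc5)c4c3)n2)c1` has not yet been measured. It differs from compound 2 in one place: 3-methylphenyl in place of 4-ethylphenyl on an aromatic carbon. The substituent keeps the same ring and loses one carbon, with a shift from the 4-position to the 3-position of the phenyl group.

Within the data shown here, no single-point step between measured compounds exists here, so the size of the step must be guessed from compound 2 alone. A change this small is expected to move the number by little, most likely within or just beyond the scatter, and if anything downward. The expected step in this assay is a number 11.2 percentage points lower from compound 2 to compound 3 (beyond the scatter). Compound 3 is expected to give about 43% in this assay, with a plausible range from 18% to 66%.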

Compound 3, a percentage reported as inhibition, at one concentration (the size of the read-out at that concentration, not a potency): 36.9%
Compound 3: the middle estimate sits 6.1 percentage points above what was measured; measured number inside the range.
By their numbers in this assay, from the lowest: compound 1; then compound 3; then compound 2.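

In this assay, among these compounds, this is the first step that can be read at a single place: a number 17.3 percentage points lower from compound 2 to compound 3 (beyond the scatter), on replacing 4-ethylphenyl with 3-methylphenyl on the aromatic carbon of the shared core. The number at this position therefore responds to a change confined to the alkyl-substituted phenyl group, with the ring kept and the rest of the molecule unchanged, so the aryl group cannot be treated as an indifferent part of the series. No measured information available here bears on the origin of this step.

The step joins two changes, the loss of one carbon and the move of the alkyl group from the 4-position to the 3-position of the phenyl group, and the compounds shown hold neither change alone, so the share of each stays open. Also open, on these data alone, is how this read-out at its one tested concentration would respond to a longer chain, an amine or a carboxylic acid on this phenyl group.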